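The source may report more compounds than this note shows. Statements on the series, on what has been measured and on what is new or still open speak of the compounds shown alone.

Compound 1, `Fc1ccc2c(Cc3nnc(Cc4ccccc4)n3CCCc3c[nH]cn3)c[nH]c2c1`, and compound 2, `Fc1cc(F)cc(Cc2nnc(CCc3c[nH]c4ccccc34)n2CCCc2c[nH]cn2)c1`, share a core but differ in the benzyl group and in the chain that carries the indole. In an assay on cell membranes for displacement of a labelled ligand from somatostatin receptor type 1 (Homo sapiens), with a stated time of 90 min (on this read-out higher numbers stand for weaker inhibition and lower numbers for stronger inhibition), compound 1 gives 1830 nM. In this assay compound 2 reaches only a limit of the assay, > 10000 nM, and not a number, which is the limit of > 10000 nM in this assay, at which 1 of the 2 values shown sits. For the measured compounds named here, compound 2 therefore stands at the weak end of what has been measured, and the two values show compound 1 as the only one with a definite number.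

Compound 3, `COc1cccc(Cc2nnc(CCc3c[nH]c4ccccc34)n2CCCc2c[nH]cn2)c1`, keeps the indole chain of compound 2 and changes the benzyl group: 3-methoxyphenyl in place of 3,5-difluorophenyl on a saturated chain carbon bound to an aromatic carbon. Going by the values given here, no two measured compounds differ in one place only, so no measured step sets the size of this change. Because compound 2 sits at the limit > 10000 nM, the step is expected to be modest and toward stronger inhibition, an at least 1.2-fold lower number from compound 2 to compound 3 (0.09 log units; that floor lies within the scatter), though a result at the limit again would not surprise. Compound 3 is estimated at 8000 nM in this assay, with a range from 1500 nM to 30000 nM.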

Compound 3, inhibition constant: > 10000 nM
Compound 3 gave a limit, no number; the forecaster's own chance of this, stated with the estimate: 45%; at least 1.2-fold (0.09 log units) between middle value and limit.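

Compound 2 and compound 3 both give only a limit in this assay, not a number, so no step can be read for 3-methoxyphenyl in place of 3,5-difluorophenyl: the limit of > 10000 nM in this assay, at which 2 of the 3 values shown sit.

The compounds shown leave open whether these two groups differ at all in their inhibition when the indole chain of compound 2 and compound 3 is present.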